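The source may hold more compounds than are shown below. What is called first, only, known or untested is meant among the compounds shown, and "the series" means these compounds.

Compound 1 `CCCCCCCCCCCCn1nnc(C(NC(=O)c2ccc(F)cc2F)c2ccccc2)n1` and compound 3 `CCCCCCCCCCCCn1nnnc1C(NC(=O)c1ccc(F)cc1F)c1ccccc1` contain the same atoms joined differently; the difference between the two cores is not broken down here. In an assay on microsomes from liver for inhibition of sterol O-acyltransferase 1 (Rattus norvegicus) (on this read-out lower numbers stand for stronger inhibition and higher numbers for weaker inhibition), compound 1 gives 490 nM, and compound 3 gives 380 nM, two numbers within the scatter of each other. Compound 2 `CCCCCCCCCCCCn1nnc(C(NC(=O)c2cccc([N+](=O)[O-])c2)c2ccccc2)n1` carries the change 3-nitrophenyl in place of 2,4-difluorophenyl on a carbonyl carbon on the core of compound 1, and in this assay compound 2 gives 80 nM, a step of a 6.1-fold lower number from compound 1 to compound 2 (0.79 log units; beyond the scatter). Compound 4 `CCCCCCCCCCCCn1nnnc1C(NC(=O)c1cccc([N+](=O)[O-])c1)c1ccccc1` carries the same change 3-nitrophenyl in place of 2,4-difluorophenyl on a carbonyl carbon on the core of compound 3 and has not yet been measured in this assay.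

The change is the same at both places, and compounds 1 and 3 start from numbers within the scatter of each other, so a step of similar size is expected on the core of compound 3: resting on the measured step of a 6.1-fold lower number from compound 1 to compound 2 (0.79 log units; beyond the scatter) and on compound 3 giving 380 nM, the expected step is a 5.8-fold lower number from compound 3 to compound 4 (0.77 log units; beyond the scatter). Among the compounds with values here, only one measured instance of the change exists, so the range is kept wide. Compound 4 is expected to give 65 nM in this assay, between 30 nM and 150 nM.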

Compound 4, half-maximal inhibitory concentration: 190 nM
The estimate for compound 4 lay 2.9-fold (0.47 log units) below the measured number; measured number above the stated range.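

In this assay, the change on the core of compound 3 gives a 2.0-fold lower number from compound 3 to compound 4 (0.30 log units; within the scatter), so the step seen on the core of compound 1 does not carry over at full size, and the two cores do not respond alike to this change: the same change on two cores in this assay, a 6.1-fold lower number (0.79 log units; beyond the scatter) from compound 1 to compound 2 and a 2.0-fold lower number (0.30 log units; within the scatter) from compound 3 to compound 4, 3.1-fold (0.49 log units) apart, beyond the scatter of two such steps. In this series, the size of the step on one core is therefore a poor guide to its size on the other, and an estimate carried across should be treated with caution. This does not show why the steps differ, and with a single pair on each core it does not show whether the gap would hold for any other group on the carbonyl carbon.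

Still open, on these data alone, is whether the two cores would also part for a different group on that carbonyl carbon, such as one bearing an amine or a carboxylic acid. Also open, as far as these compounds go, is whether the gap would persist if a shorter chain replaced the long alkyl chain shared by all four compounds.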